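The compounds below may be only part of what the source reports. "The series", "measured", "known", "first", "only" and "open" are said of these compounds alone.

Measured so far, in a functional assay on MCF7 cells (Homo sapiens) for cytotoxicity, read by MTT assay, with a stated time of 48 h; a higher number here means a weaker inhibitor, a lower number a stronger inhibitor:
compound 1 `O=C(CSCc1nc2cc([N+](=O)[O-])ccc2[nH]1)c1ccc(Cl)cc1` gives 2800 nM.
compound 2 `CCOC(=O)CSCc1nc2cc([N+](=O)[O-])ccc2[nH]1` reaches only a limit of the assay, > 100000 nM, not a number.
compound 3 `NC(=O)CSCc1nc2cc([N+](=O)[O-])ccc2[nH]1` gives 19700 nM.

Compound 3 carries the highest of the two numbers in this assay; the nearest is compound 1, the gap being a 7.0-fold higher number from compound 1 to compound 3 (0.85 log units; beyond the scatter). Compound 2 stands at a limit, (the limit of > 100000 nM in this assay, at which 1 of the 3 values shown sits), so its distance from compound 3 is known only as an at least 5.0-fold lower number from compound 2 to compound 3 (0.70 log units; beyond the scatter).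

Compound 4 `CC1=NN(C(=O)CSCc2nc3cc([N+](=O)[O-])ccc3[nH]2)C(=O)C1` differs from compound 3 by a group of 7 heavy atoms (4 carbon, 2 nitrogen, 1 oxygen; one five-membered non-aromatic ring with 2 hetero atoms) in place of one nitrogen atom, on a carbonyl carbon. For the measured compounds named here, the steps that bear on this are the two that change the group on the carbonyl carbon: a 7.0-fold higher number from compound 1 to compound 3 (0.85 log units; beyond the scatter) and an at least 5.0-fold lower number from compound 2 to compound 3 (0.70 log units; beyond the scatter). Among the groups tried at that position, the 4-chlorophenyl ketone of compound 1 gave the lowest number and the ethoxy ester of compound 2 only a limit, while the amino of compound 3 lies between. The entering group is again a larger, ring-bearing substituent on the carbonyl carbon, closer in character to compound 1 than to compound 2, so a modestly lower number is expected for compound 4, a 3.9-fold lower number from compound 3 to compound 4 (0.60 log units; beyond the scatter). Compound 4 is estimated at 5000 nM, with a range from 1500 nM to 20000 nM.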

Compound 4, half-maximal inhibitory concentration: 8070 nM
Beside the measured number, compound 4's estimate is 1.6-fold (0.21 log units) below it; the range from low to high includes it.
By their numbers in this assay, from the lowest: compound 1; then compound 4; then compound 3. At a limit, above all of these: compound 2.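

In this assay, the new ring-bearing group gives a number distinct from both neighbouring groups on the carbonyl carbon: a 2.4-fold lower number from compound 3 to compound 4 (0.39 log units; beyond the scatter), and a 2.9-fold higher number from compound 1 to compound 4 (0.46 log units; beyond the scatter). The entering group and 4-chlorophenyl both count 7 heavy atoms, so among the compounds shown, heavy-atom count alone does not fix the number at this position. The ethoxy comparison gives only a bound, an at least 12-fold lower number from compound 2 to compound 4 (1.09 log units; beyond the scatter), as compound 2 is a limit and not a number: the limit of > 100000 nM in this assay, at which 1 of the 4 values shown sits.

The compounds shown leave open whether the non-aromatic ring itself matters, or whether a simple dimethylamino group on the same carbonyl carbon would give a similar number. They also leave open where an unsubstituted phenyl would fall relative to the 4-chlorophenyl of compound 1.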